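Swapping an indole for a methylated indazole

The compounds below may be only part of what the source reports. "The series", "measured", "known", "first", "only" and "open" are said of these compounds alone.

Measured so far:
compound 1 `COc1cc(-c2ccnc3cc(-c4ccc5cc[nH]c5c4)nn23)cc(OC)c1OC`: 170 nM
compound 2 `COc1cc(-c2cc3nccc(-c4c[nH]c5ccccc45)n3n2)cc(OC)c1OC`: > 10000 nM

For the measured compounds named here, in a functional assay on A549 cells (Homo sapiens) for inhibition, read by CCK-8 assay, with a stated time of 48 h (on this read-out higher numbers stand for weaker inhibition and lower numbers for stronger inhibition), compound 1 gives 170 nM, the only plain number among the two values shown. In this assay compound 2 shows > 10000 nM, which is a limit of the assay and not a number; this is the limit of > 10000 nM in this assay, at which 1 of the 2 values shown sits. Compound 3 `COc1cc(-c2ccnc3cc(-c4ccc5cnn(C)c5c4)nn23)cc(OC)c1OC` differs from compound 1 by 1-methyl-1H-indazol-6-yl in place of 1H-indol-6-yl on an aromatic carbon. No step between measured compounds is shown, so the size of this change is open. Compound 3 is expected to be somewhat weaker, with an estimated step of a 2.9-fold higher number from compound 1 to compound 3 (0.47 log units; beyond the scatter) beyond the scatter. Compound 3 is estimated at 500 nM, within 120 nM to 3000 nM.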

Compound 3, half-maximal inhibitory concentration: 233 nM
Estimate against measurement, compound 3: 2.1-fold (0.33 log units) above; the measured number falls inside the stated range.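

In this assay putting 1-methyl-1H-indazol-6-yl in place of 1H-indol-6-yl gives a 1.4-fold higher number from compound 1 to compound 3 (0.14 log units; within the scatter) and so leaves the cell activity effectively unchanged. This place on the shared core therefore accepts a group with 0 hydrogen-bond donors, so the donor of the 1H-indol-6-yl group is not needed to keep this level of activity.

Going by these compounds, whether an amine, a carboxylic acid or a longer chain would be accepted at this place stays open. Nothing measured here explains why the swap is tolerated.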